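This account rests on a few compounds, and the source may have more. Where it says the series, first, only, none or still open, it means among the compounds named here.

Measured compounds:
Compound 1, `O=c1nc(N2CCN(NCC3CCCCC3)CC2)sc2c([N+](=O)[O-])cc(C(F)(F)F)cc12`: 29.3 ug/mL
Compound 2, `CC(C)CN(CC(C)C)N1CCN(c2nc(=O)c3cc(C(F)(F)F)cc([N+](=O)[O-])c3s2)CC1`: > 64 ug/mL

In an ADME assay on Vero cells (Chlorocebus sabaeus) for cytotoxicity, read by MTT assay, with a stated time of 72 h (on this read-out higher numbers stand for lower toxicity in this test and lower numbers for higher toxicity in this test), compound 1 gives 29.3 ug/mL. Compound 2 does not give a number in this assay; its value, > 64 ug/mL, is a limit of the test. Where compound 2 stands is therefore known only as a range that begins at the limit of > 64 ug/mL in this assay, at which 1 of the 2 values shown sits. Within the data shown here, the one measured step is an at least 2.1-fold higher number from compound 1 to compound 2 (0.33 log units; beyond the scatter), and it is an open-ended step, since compound 2 sits at the limit.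

Compound 3, `CN(CC1CCCCC1)N1CCN(c2nc(=O)c3cc(C(F)(F)F)cc([N+](=O)[O-])c3s2)CC1`, differs from compound 2 in a single place: (cyclohexylmethyl)(methyl)amino in place of diisobutylamino on an amine nitrogen in a ring. The group that enters carries the cyclohexylmethyl group of compound 1 together with a methyl group, so compound 3 stands between compound 1 and compound 2 in its make-up. The step from compound 1 to compound 2 is the only one that bears on this change. For compound 3 a small step downward, an at least 1.4-fold lower number from compound 2 to compound 3 (0.15 log units; that floor lies within the scatter), is expected, though the limit leaves its true size open. Compound 3 is estimated to give 45 ug/mL, within a range from 25 ug/mL to 80 ug/mL.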

Compound 3, half-maximal cytotoxic concentration: > 64 ug/mL
Compound 3 ended at the assay's limit; the forecaster's own chance of this, stated with the estimate: 35%; middle value at least 1.4-fold (0.15 log units) away from the limit.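

Methyl in place of hydrogen on an amine nitrogen gives an at least 2.1-fold higher number from compound 1 to compound 3 (0.33 log units; beyond the scatter) in this assay, and on this read-out a higher number stands for lower toxicity in this test. Compound 1 and compound 2 differ in the whole group on that nitrogen, whereas compound 1 and compound 3 both keep the cyclohexylmethyl group, so this pair shows that the hydrogen-to-methyl change alone is enough to move the number beyond the usual scatter, and that the diisobutylamino group of compound 2 is not needed for it. The step between compound 2 and compound 3 cannot be read, because both compounds sit at the same limit of the test rather than at a number: the limit of > 64 ug/mL in this assay, at which 2 of the 3 values shown sit.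

On these data alone, how far the true values of compound 2 and compound 3 lie past that limit stays unknown, so the diisobutylamino and (cyclohexylmethyl)(methyl)amino groups cannot be placed in any order. Whether an ethyl group or a longer chain in place of the methyl would also reach the limit is open as well.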